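Thiophen-3-yl for furan-2-yl: compound 3 to compound 4

This account rests on a few compounds, and the source may have more. Where it says the series, first, only, none or still open, it means among the compounds named here.

Going by the values given here, compound 3 `Oc1cccc(-c2cc(-c3ccco3)nc(-c3ccccc3Cl)c2)c1` gives 0% in an assay on isolated protein for inhibition of DNA topoisomerase 1 (Homo sapiens), with a stated time of 30 min, tested at 100 uM (a higher number here means a stronger effect of the compound at the concentration tested, a lower number a weaker effect), the lowest of the three numbers so far. Among the compounds with values here, compound 2 `Oc1ccc(-c2cc(-c3ccsc3)nc(-c3cccc(Cl)c3)c2)cc1` gives 26% and compound 1 `Oc1cccc(-c2cc(-c3ccc(Cl)cc3)nc(-c3ccco3)c2)c1` gives 27.1%; the only single-point step measured, a number 27.1 percentage points lower from compound 1 to compound 3 (beyond the scatter), concerns the chlorophenyl group and not the heteroaryl. Compound 4 `Oc1cccc(-c2cc(-c3ccsc3)nc(-c3ccccc3Cl)c2)c1` differs from compound 3 by thiophen-3-yl in place of furan-2-yl on an aromatic carbon. Within the data shown here, no measured step covers this exchange; compounds 1 and 2 carry furan-2-yl and thiophen-3-yl but differ elsewhere as well, so only their two values can be noted. The step of a number 5 percentage points higher from compound 3 to compound 4 (within the scatter) is therefore expected to stay within the scatter. Compound 4 is estimated at 5%, between 0% and 20%.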

Compound 4, a percentage reported as inhibition, at one concentration (the size of the read-out at that concentration, not a potency): 0%
For compound 4 the middle estimate is 5 percentage points above the measured one; the measured number falls inside the stated range.
By their numbers in this assay, from the lowest: compounds 3 and 4 (each within the scatter of the next); then compounds 2 and 1 (each within the scatter of the next).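

In this assay, going by these compounds alone, the exchange gives no change at the digits printed from compound 3 to compound 4 (within the scatter) and so shows, for the first time in a matched pair, that thiophen-3-yl and furan-2-yl next to the ring nitrogen cannot be told apart when 2-chlorophenyl is present. Both compounds sit at the bottom of the read-out, so any loss from this exchange would not show here. No measurement given here explains the lack of change.

Open, as far as these compounds go, is whether the exchange stays as silent with the 4-chlorophenyl group of compound 1, which gives 27.1% in this assay. Also open, from the compounds shown here alone, is whether an amine or a carboxylic acid at this place would lift the read-out.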